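A few compounds are considered here, and "the series" means these few. Any claim that something is new, unique, unknown or untested is made for them only; others in the source may bear on it.

Measured compounds in the series:

compound 1, `COc1cccc(-c2c(C)nn(-c3nc(-c4ccc(Cl)c(Cl)c4)c(SC(C)C)s3)c2C(=O)O)c1` — 14000 nM
compound 2, `COc1ccc(C)cc1-c1c(C)nn(-c2nc(-c3ccc(Cl)c(Cl)c3)c(SC(C)C)s2)c1C(=O)O` — 9500 nM
compound 3, `Cc1nn(-c2nc(-c3ccc(Cl)c(Cl)c3)c(SC(C)C)s2)c(C(=O)O)c1Cc1ccccc1[N+](=O)[O-]` — 20000 nM

All three numbers come from a functional assay on BJAB cells (Homo sapiens) for antiproliferative activity, with a stated time of 4 days; a lower number here means that less compound is needed, a higher number that more compound is needed for the effect. Compound 3 gives the highest of the three numbers in this assay. Its distance from compound 1 is small: a 1.4-fold higher number from compound 1 to compound 3 (0.15 log units; within the scatter). Its distance from compound 2 is larger: a 2.1-fold higher number from compound 2 to compound 3 (0.32 log units; beyond the scatter), a modest step that clears the scatter. The two aryl-bearing compounds themselves sit close together: a 1.5-fold lower number from compound 1 to compound 2 (0.17 log units; within the scatter).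

Compound 4, `Cc1nn(-c2nc(-c3ccc(Cl)c(Cl)c3)c(SC(C)C)s2)c(C(=O)O)c1-c1cccc(Cl)c1C`, is the next member to be measured. It differs from compound 3 in one place: 3-chloro-2-methylphenyl in place of 2-nitrobenzyl on an aromatic carbon.

Among the compounds with values here, the steps that bear on this change are the two that exchange an aryl group for the 2-nitrobenzyl group, that is a 1.4-fold higher number from compound 1 to compound 3 (0.15 log units; within the scatter) and a 2.1-fold higher number from compound 2 to compound 3 (0.32 log units; beyond the scatter). Both point the same way: the 2-nitrobenzyl member carries a number that is the same or somewhat higher than the aryl members. Going back from 2-nitrobenzyl to an aryl group is therefore expected to give a somewhat lower number in this assay, though with the step between compound 1 and compound 2 within the scatter, the particular substitution pattern of the incoming 3-chloro-2-methylphenyl group cannot be read off the shown numbers. The expected step is a 2.0-fold lower number from compound 3 to compound 4 (0.30 log units; within the scatter), in the downward direction and of small to modest size. For compound 4 the estimate in this assay is 10000 nM, with a range from 4000 nM to 25000 nM.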

Compound 4, half-maximal effective concentration: 5100 nM
For compound 4 the middle estimate is 2.0-fold (0.29 log units) above the measured one; the range from low to high includes it.
By their numbers in this assay, from the lowest: compounds 4, 2, 1 and 3 (each within the scatter of the next, the first and the last beyond it).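

In this assay the exchange of 2-nitrobenzyl for 3-chloro-2-methylphenyl gives a 3.9-fold lower number from compound 3 to compound 4 (0.59 log units; beyond the scatter) and is the widest step yet seen at this aromatic carbon, which bears the group next to the ring atom with the carboxy group. Within the data shown here, it also gives the first aryl-for-aryl change beyond the scatter, a 2.7-fold lower number from compound 1 to compound 4 (0.44 log units; beyond the scatter), whereas the other such change, a 1.9-fold lower number from compound 2 to compound 4 (0.27 log units; within the scatter), stays within it, as the step between compound 1 and compound 2 did, so the aryl substitution pattern can now be seen to matter for one pair but not for the other. Nothing shown bears on what lies behind these differences.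

The compounds shown do not separate the contribution of the chlorine from that of the methyl in the 3-chloro-2-methylphenyl group, and a plain phenyl, a 3-chlorophenyl or a 2-methylphenyl at this carbon would be needed to do so. Also open, on these data alone, is whether a benzyl group without the nitro substituent, or an aryl group carrying an amine, would follow the aryl members or compound 3 in this assay.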